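The compounds below may be only part of what the source reports. "The series", "measured", "known", "first", "only" and "open" are said of these compounds alone.

Of the compounds shown here, three have been measured in a functional assay on CCRF-CEM cells (Homo sapiens) for cytotoxicity, read by sulforhodamine B assay, with a stated time of 48 h, tested at 10 uM; a lower number here means a stronger effect, a higher number a weaker effect of the compound at the concentration tested. Compound 1 `COc1ccc(-c2cc(/C=C/C(=O)c3ccc(OC)c(OC)c3)[nH]n2)cc1` gives -39% in this assay. Compound 2 `COc1cc(-c2cc(/C=C/C(=O)c3ccc(Cl)c(Cl)c3)[nH]n2)cc(OC)c1OC` gives 9%. Compound 3 `COc1ccc(-c2cc(/C=C/C(=O)c3cc(OC)c(OC)c(OC)c3)[nH]n2)cc1OC` gives -15%, which places it second highest of the three numbers, with compound 1 giving a lower number, beyond the scatter, and compound 2 giving a higher number, also beyond the scatter. Compound 3 thus sits midway between its two neighbours.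

Compound 4 `COc1cc(C(=O)/C=C/c2cc(-c3cc(OC)c(OC)c(OC)c3)n[nH]2)cc(OC)c1OC` has not yet been measured in this assay. The change from compound 3 to compound 4 is methoxy in place of hydrogen on an aromatic carbon. Among the compounds with values here, no step between two measured compounds of this kind is available, so its size must be estimated from the three numbers alone. Given that compound 3 gives -15% and compound 2, which also carries three methoxy groups on the ring attached to the shared core, gives 9%, a step upward of modest size from compound 3 to compound 4 is expected, a number 15 percentage points higher from compound 3 to compound 4 (beyond the scatter), though compound 2 differs in the other ring too. Compound 4 is therefore estimated to give about 0% in this assay, within a range from -25% to 25%.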

Compound 4, a percentage reported as activity, at one concentration (the size of the read-out at that concentration, not a potency): -7%
Estimate against measurement, compound 4: 7 percentage points above; the measured number falls inside the stated range.
By their numbers in this assay, from the lowest: compound 1; then compounds 3 and 4 (each within the scatter of the next); then compound 2.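

In this assay, within the data shown here, methoxy in place of hydrogen on an aromatic carbon, ortho to a methoxy group and meta to a large group, gives a number 8 percentage points higher from compound 3 to compound 4 (within the scatter) and is the first change that can be read in one place. At this position, the added methoxy group therefore leaves the read-out within the usual scatter, so compound 4 and compound 3 cannot be told apart at the concentration tested. No measured property bears on this result, so nothing can be said about its origin.

The compounds shown leave open whether another group at this position, such as a hydroxyl, an amine or a carboxylic acid, would give a step beyond the scatter. They also leave open whether methoxy in place of hydrogen gives a step of similar size elsewhere on the shared core.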